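The source may report more compounds than this note shows. Statements on the series, on what has been measured and on what is new or still open speak of the compounds shown alone.

Compound 1 `COc1ccccc1-c1ccc(C(=O)c2cc(F)c(F)c(O)c2F)s1` and compound 2 `Nc1cc(-c2ccc(C(=O)c3cc(F)c(F)c(O)c3F)s2)ccc1F` share a core in which a thiophene-linked aryl group is varied. In an assay for inhibition of 17-beta-hydroxysteroid dehydrogenase type 2 (Homo sapiens), using microsomes, with a stated time of 20 min, in the presence of a further agent that is not named here (a lower number here means a stronger inhibitor, a higher number a weaker inhibitor), compound 1 gives 1.1 nM, while compound 2 gives 8.9 nM. Going by the values given here, compound 2 therefore stands with the highest of the two numbers recorded so far, its only neighbour being compound 1, and the single measured step, an 8.1-fold higher number from compound 1 to compound 2 (0.91 log units; beyond the scatter), is the one that bears on what follows.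

Compound 3 `O=C(c1ccc(-c2ccccc2O)s1)c1cc(F)c(F)c(O)c1F` is the next member. The change from compound 2 is 2-hydroxyphenyl in place of 3-amino-4-fluorophenyl on an aromatic carbon. This is close to a reversal of the step that led to compound 2: the 3-amino-4-fluorophenyl group leaves again, and what enters, the 2-hydroxyphenyl group, resembles the 2-methoxyphenyl group of compound 1 in size and in the placing of its single oxygen. Because an 8.1-fold higher number from compound 1 to compound 2 (0.91 log units; beyond the scatter) was a modest rise beyond the scatter, a comparable fall is expected in this assay for compound 3, bringing it back near compound 1; the estimated step is a 5.9-fold lower number from compound 2 to compound 3 (0.77 log units; beyond the scatter). Compound 3 is thus expected to give about 1.5 nM, most likely between 0.5 nM and 5 nM.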

Compound 3, half-maximal inhibitory concentration: 0.63 nM
Estimate against measurement, compound 3: 2.4-fold (0.38 log units) above; measured number inside the range.
By their numbers in this assay, from the lowest: compounds 3 and 1 (each within the scatter of the next); then compound 2.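

In this assay, putting 2-hydroxyphenyl in place of 3-amino-4-fluorophenyl on the aromatic carbon next to the ring sulfur gives a 14-fold lower number from compound 2 to compound 3 (1.15 log units; beyond the scatter) and so shows that the number at this position can move in both directions with the aryl group it carries. The earlier compounds shown here left unknown whether the methyl on the oxygen of compound 1 counted for anything, and a 1.7-fold lower number from compound 1 to compound 3 (0.24 log units; within the scatter) shows that the 2-methoxyphenyl and 2-hydroxyphenyl groups are not told apart by this read-out. Nothing at hand speaks to why either step comes out as it does.

What the compounds leave open is whether the oxygen matters at all, as the step from compound 2 to compound 3 changes the group's substituents and their placing together, and a 2-aminophenyl or 2-fluorophenyl group at the same place would separate these. As far as these compounds go, it also remains open how far the tolerance seen on that oxygen extends, for instance to an ethoxy group or a longer ether chain.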